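Swapping an aromatic ring for cyclopropyl on the shared core

The source may hold more compounds than are shown below. What is called first, only, known or untested is meant among the compounds shown, and "the series" means these compounds.

Of the compounds shown here, three built on one shared core have been measured in an assay on HEK293 cells for activation of Kir3.1/Kir3.2 (Homo sapiens), read by thallium flux; on this read-out higher numbers stand for an effect only at larger amounts of compound and lower numbers for an effect already at smaller amounts. Compound 1 `Cc1cc(NC(=O)Cn2nnc(-c3ccccn3)n2)n(C2CCCCC2)n1` gives 14600 nM. Compound 2 `Cc1cc(NC(=O)Cn2nnc(-c3ccc(Cl)c(Cl)c3)n2)n(C2CCCCC2)n1` gives 1220 nM, and compound 3 `Cc1cc(NC(=O)Cn2nnc(-c3ccc(F)c(F)c3)n2)n(C2CCCCC2)n1` gives 116 nM. For the measured compounds named here, compound 3 therefore stands lowest of the three, with an 11-fold lower number from compound 2 to compound 3 (1.02 log units; beyond the scatter) and a 130-fold lower number from compound 1 to compound 3 (2.10 log units; beyond the scatter) both beyond the scatter, making it the most potent compound measured so far.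

Compound 4 `Cc1cc(NC(=O)Cn2nnc(C3CC3)n2)n(C2CCCCC2)n1` differs from compound 3 by cyclopropyl in place of 3,4-difluorophenyl on an aromatic carbon. Going by the values given here, none of the measured steps makes this kind of change: a 12-fold lower number from compound 1 to compound 2 (1.08 log units; beyond the scatter), a 130-fold lower number from compound 1 to compound 3 (2.10 log units; beyond the scatter) and an 11-fold lower number from compound 2 to compound 3 (1.02 log units; beyond the scatter) all exchange one aromatic ring for another at the same place, and all three are large. They show that this position is sensitive to what sits there, but they do not say what happens when the aromatic ring is removed altogether. Given that sensitivity, a sizeable step is expected rather than none; with no direct precedent, the direction is a guess, and a weakening is taken as more likely than a gain. Compound 4 is therefore estimated at 3000 nM, between 600 nM and 15000 nM, a step of a 26-fold higher number from compound 3 to compound 4 (1.41 log units; beyond the scatter) in this assay.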

Compound 4, half-maximal effective concentration: > 3000 nM
Compound 4: only a limit was reported (the forecaster's own chance of this, stated with the estimate: 10%); the middle value lies on the limit itself.
By their numbers in this assay, from the lowest: compound 3; then compound 2; then compound 1.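

Putting cyclopropyl in place of an aromatic ring at this carbon moves the number up, which the earlier swaps of one aromatic ring for another could not show: there is an at least 25-fold higher number from compound 3 to compound 4 (1.41 log units; beyond the scatter) and an at least 2.4-fold higher number from compound 2 to compound 4 (0.39 log units; beyond the scatter). Compound 4 carries a limit rather than a number, so these steps are minimum sizes and the step from compound 1 to compound 4 cannot be read: the limit of > 3000 nM in this assay, at which 1 of the 4 values shown sits. Compound 3 and compound 2, with their substituted phenyl rings, therefore act at smaller amounts than compound 4, while compound 1, with pyridin-2-yl, cannot be placed relative to it.

Going by these compounds, how far compound 4 really lies past its limit stays open. So does whether the aromatic ring itself or simply a larger group matters here, which a plain phenyl, a butyl chain or an amine at this carbon could help separate.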